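Working notes: 1-chloroethenyl carbonyl in place of vinylcarbonyl

The source may report more compounds than this note shows. Statements on the series, on what has been measured and on what is new or still open speak of the compounds shown alone.

Measured in a functional assay on NCI-H1975 cells (Homo sapiens) for antiproliferative activity, read by MTT assay, with a stated time of 72 h; on this read-out lower numbers stand for stronger inhibition and higher numbers for weaker inhibition:
compound 1 `C=C(Cl)C(=O)Nc1cc(Nc2nccc(-c3cn(C)c4ccccc34)n2)c(OC)cc1N(C)CCN(C)C`: 1290 nM
compound 2 `C=CC(=O)Nc1cc(Nc2nc(C)cc(-c3cn(C)c4ccccc34)n2)c(OC)cc1N(C)CCN(C)C`: 4810 nM

Within the data shown here, compound 2 stands highest of the two numbers; its nearest neighbour is compound 1, whose number is lower by a margin beyond the scatter, but the two structures differ in more than one place, so no single step is isolated. Compound 3 `C=C(Cl)C(=O)Nc1cc(Nc2nc(C)cc(-c3cn(C)c4ccccc34)n2)c(OC)cc1N(C)CCN(C)C` differs from compound 2 by chloro in place of hydrogen on a double-bonded chain carbon bound to a carbonyl carbon. Among the measured compounds shown here, no measured pair isolates this change. For compound 3 a modest step toward a lower number in this assay is expected, a 1.9-fold lower number from compound 2 to compound 3 (0.28 log units; within the scatter), close to the edge of the scatter. Compound 3 is estimated at 2500 nM, with a range from 900 nM to 7000 nM.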

Compound 3, half-maximal inhibitory concentration: 2230 nM
The estimate for compound 3 lay 1.1-fold (0.05 log units) above the measured number, and the stated range covers the measured number.
By their numbers in this assay, from the lowest: compounds 1 and 3 (each within the scatter of the next); then compound 2.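

In this assay, among these compounds, chloro in place of hydrogen on a double-bonded chain carbon bound to a carbonyl carbon gives a 2.2-fold lower number from compound 2 to compound 3 (0.33 log units; beyond the scatter) as the first isolated reading of this change, modest in size. Methyl in place of hydrogen on an aromatic carbon gives a 1.7-fold higher number from compound 1 to compound 3 (0.24 log units; within the scatter) and so cannot be told apart from repeat variation here. Nothing measured explains the chloro step.

From the compounds shown here alone, whether the chloro step carries over to the core of compound 1 stays open. So does how fluoro, bromo or a nitrile would read on that double-bonded chain carbon.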